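Aryl substituent swap on the formyl-bearing core

This account rests on a few compounds, and the source may have more. Where it says the series, first, only, none or still open, it means among the compounds named here.

Compound 3 `O=Cc1c(-c2ccc(Br)cc2)nc2sc(Cc3ccc(Cl)cc3)nn12` gives the lowest number of the two numbers measured in an ADME assay on CCRF-CEM cells (Homo sapiens) for cytotoxicity, with a stated time of 72 h (on this read-out higher numbers stand for weaker inhibition and lower numbers for stronger inhibition), at 4000 nM. Its nearest neighbour is compound 2 `O=Cc1c(-c2ccc(F)cc2)nc2sc(Cc3ccc(Cl)cc3)nn12`, which in this assay gives 17000 nM. The step of a 4.3-fold lower number from compound 2 to compound 3 (0.63 log units; beyond the scatter) is modest but beyond the scatter. Compound 1 `Cc1ccc(-c2cn3nc(Cc4ccc(Cl)cc4)sc3n2)cc1` gives only a limit in this assay, > 250000 nM; that is a limit of the assay and not a number.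

Compound 4 `Cc1ccc(-c2nc3sc(Cc4ccc(Cl)cc4)nn3c2C=O)cc1` is the next step. The change from compound 3 is methyl in place of bromo on an aromatic carbon. Within the data shown here, no measured step covers a bromo-to-methyl exchange; the only step measured on this position, from compound 2 to compound 3, exchanges one halogen for another, so it bears on compound 4 only as a sign that this position moves the number by a modest amount. Compound 1 carries the same methyl as compound 4 but differs from it elsewhere, so its limit cannot be read as a step to compound 4.

The expectation for compound 4 is therefore a modest step of a 2.0-fold higher number from compound 3 to compound 4 (0.30 log units; within the scatter), toward a higher number, with wide uncertainty. Compound 4 is estimated at 8000 nM in this assay, within a range from 3000 nM to 25000 nM.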

Compound 4, half-maximal inhibitory concentration: 17000 nM
The estimate for compound 4 lay 2.1-fold (0.33 log units) below the measured number; low and high end bracket the measured number.
By their numbers in this assay, from the lowest: compound 3; then compounds 2 and 4 (each within the scatter of the next). At a limit, above all of these: compound 1.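

On this position the number does not follow a simple halogen-to-methyl trend in this assay: the exchange of 4-bromophenyl for 4-methylphenyl gives a 4.3-fold higher number from compound 3 to compound 4 (0.63 log units; beyond the scatter), a step of the same printed size as a 4.3-fold lower number from compound 2 to compound 3 (0.63 log units; beyond the scatter) but running the other way. The methyl and fluoro groups do not separate, with no change at the digits printed from compound 2 to compound 4 (within the scatter), so among the three groups shown only bromo stands apart from the other two, and compound 3 has the lowest number of the series. Compound 4 also gives the first comparison with the same 4-methylphenyl on both sides, and the step with formyl in place of hydrogen, an at least 14-fold lower number from compound 1 to compound 4 (1.16 log units; beyond the scatter), is large but starts from a limit, which is not a number: the limit of > 250000 nM in this assay, at which 1 of the 4 values shown sits.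

As far as these compounds go, whether the lower number of compound 3 is particular to bromo or extends to chloro, iodo or an amine at this place stays open. Formyl is compared only with hydrogen, and only with 4-methylphenyl present, so the effect of a hydroxymethyl or a nitrile in its place, and the size of this step with 4-bromophenyl, remain unknown.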